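The source may hold more compounds than are shown below. What is called first, only, known or untested is meant among the compounds shown, and "the series" means these compounds.

Compounds 1 to 4 share an amide-linked pair of rings but differ in the core and in the group on the outer ring. Compound 1 `CC(C)(C)c1ccc(/C=C/C(=O)Nc2ccc3c(c2)OCCN3)cc1` carries a tert-butyl group, and in a functional assay on CHO cells for inhibition of transient receptor potential cation channel subfamily V member 1 (Homo sapiens) (a higher number here means a weaker inhibitor, a lower number a stronger inhibitor), compound 1 gives 57 nM. Compound 2 `CC(C)(C)c1ccc(/C=C/C(=O)Nc2ccc3c(c2)NC(=O)CO3)cc1` reaches only the limit of this assay, > 4000 nM. Compound 3 `O=C(/C=C/c1ccccc1)Nc1ccc2c(c1)OCCO2` likewise sits at a limit in this assay, > 4000 nM, so no number is known for it (the limit of > 4000 nM in this assay, at which 2 of the 3 values shown sit). Compound 4 `CCCCc1ccc(/C=C/C(=O)Nc2ccc3c(c2)OCCO3)cc1` differs from compound 3 by butyl in place of hydrogen on an aromatic carbon. For the measured compounds named here, no measured pair shows this exact change on this core. Still, the reading of compound 1, 57 nM, points to an alkyl group accompanying strong inhibition. A large step toward stronger inhibition is expected, an at least 13-fold lower number from compound 3 to compound 4 (1.12 log units; beyond the scatter). Compound 4 is estimated at 300 nM, between 40 nM and 4000 nM.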

Compound 4, half-maximal inhibitory concentration: 2700 nM
For compound 4 the middle estimate is 9.0-fold (0.95 log units) below the measured one; the measured number falls inside the stated range.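

Butyl in place of hydrogen on an aromatic carbon, para to a large group, gives this core a measured number in this assay rather than a limit. The change amounts to an at least 1.4-fold lower number from compound 3 to compound 4 (0.17 log units; that floor lies within the scatter), so it cannot yet be told apart from the usual scatter. The step is only a floor because compound 3 is a limit and not a number: the limit of > 4000 nM in this assay, at which 2 of the 4 values shown sit.

Still open, as far as these compounds go, is how a longer chain such as hexyl, an amine or a carboxylic acid would read at this position. Also open, from the compounds shown here alone, is how tert-butyl, carried by compound 1 and compound 2, would read on this core.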